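This account rests on a few compounds, and the source may have more. Where it says the series, first, only, none or still open, it means among the compounds named here.

Of the compounds shown here, two have been measured in a functional assay on HeLa cells (Homo sapiens) for cytotoxicity, read by MTT assay, with a stated time of 48 h; on this read-out lower numbers stand for stronger inhibition and higher numbers for weaker inhibition. Compound 2 `COc1ccc(-c2nc3ccccn3c2C(=O)/C=C\Nc2ccc3cc[nH]c3c2)cc1` gives 15300 nM, and compound 1 `COc1ccc(-c2nc3ccccn3c2C(=O)/C=C\Nc2ccc3[nH]ccc3c2)cc1` gives 13600 nM; the gap between them lies within the scatter. Compound 3 `COc1ccc(-c2nc3ccccn3c2C(=O)/C=C\Nc2ccc3ncccc3c2)cc1` differs from compound 2 by quinolin-6-yl in place of 1H-indol-6-yl on an amine nitrogen. Going by the values given here, the one measured step, a 1.1-fold higher number from compound 1 to compound 2 (0.05 log units; within the scatter), only shifts where the ring is joined and stays within the scatter; no measured step replaces the 1H-indol-6-yl group by another ring, so this change is untested. Compound 3 is therefore expected to land near 14000 nM, between 5000 nM and 40000 nM. That estimate means a step of a 1.1-fold lower number from compound 2 to compound 3 (0.04 log units; within the scatter), within the scatter.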

Compound 3, half-maximal inhibitory concentration: 4850 nM
Beside the measured number, compound 3's estimate is 2.9-fold (0.46 log units) above it; the whole stated range lies above it.
By their numbers in this assay, from the lowest: compound 3; then compounds 1 and 2 (each within the scatter of the next).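

Unlike the shift of the ring junction between the two indoles, replacing either indole on the amine nitrogen with quinolin-6-yl lowers the number in this assay (a 3.2-fold lower number from compound 2 to compound 3 (0.50 log units; beyond the scatter)) and (a 2.8-fold lower number from compound 1 to compound 3 (0.45 log units; beyond the scatter)). So this position does respond to the choice of ring. The swap changes ring size and exchanges a hydrogen-bond donor for an acceptor, and no available evidence explains the lower number. Which of those differences matters stays open. A naphthalen-2-yl group, with carbon-only rings, or an isoquinolin-6-yl group could help separate them.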